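This account rests on a few compounds, and the source may have more. Where it says the series, first, only, none or still open, it means among the compounds named here.

Of the compounds shown here, three of a shared core have been tested in an assay on HeLa cells for displacement of a labelled ligand from thyroid hormone receptor beta (Homo sapiens); on this read-out lower numbers stand for stronger inhibition and higher numbers for weaker inhibition. Compound 1, `CC(C)c1cc(Cn2ccc3cc(OCC(=O)O)ccc32)ccc1O`, gives 1.04 nM. Compound 2, `Cc1cn(Cc2ccc(O)c(C(C)C)c2)c2ccc(OCC(=O)O)cc12`, gives 0.38 nM. Compound 3, `Cc1cn(Cc2ccc(O)c(C(C)C)c2)c2c(Cl)cc(OCC(=O)O)cc12`, gives 0.09 nM. On these numbers compound 2 stands second highest of the three: it lies below compound 1 and above compound 3, and both gaps are beyond the scatter. Two single changes have been measured. Adding a methyl on an aromatic carbon gave a 2.7-fold lower number from compound 1 to compound 2 (0.44 log units; beyond the scatter), and adding a chloro on another aromatic carbon gave a 4.2-fold lower number from compound 2 to compound 3 (0.63 log units; beyond the scatter).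

Compound 4, `Cc1cn(Cc2ccc(O)c(C3CCCCC3)c2)c2ccc(OCC(=O)O)cc12`, differs from compound 2 in one place: cyclohexyl in place of isopropyl on an aromatic carbon. Among the compounds with values here, neither measured step touches this group, so the two steps show only that single small changes on the core shifted the number by modest amounts, in both cases downward. Within the data shown here, for a change that swaps one carbon group for a larger one at the isopropyl position there is no measured precedent here, so the expectation is uncertain. Compound 4 is estimated to give 0.8 nM in this assay. For compound 4 the expected range runs from 0.2 nM to 4 nM. This expectation amounts to a 2.1-fold higher number from compound 2 to compound 4 (0.32 log units; beyond the scatter), a modest rise in the number, though a result within the scatter would not surprise.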

Compound 4, inhibition constant: 8.04 nM
The estimate for compound 4 lay 10-fold (1.00 log units) below the measured number; the whole stated range lies below it.
By their numbers in this assay, from the lowest: compound 3; then compound 2; then compound 1; then compound 4.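

In this assay, within the data shown here, cyclohexyl in place of isopropyl gave a 21-fold higher number from compound 2 to compound 4 (1.33 log units; beyond the scatter), the first measured single change that raises the number and the largest of the three, so this position, ortho to a hydroxy group, is far from indifferent to which carbon group it carries. The swap goes from three carbons and no ring to six carbons in a non-aromatic ring, with no hydrogen-bond donor, hydrogen-bond acceptor or net charge on either group, so a change made only of carbon is enough to produce a large step here. Nothing shown here accounts for why the number rose.

The compounds shown leave open whether the rise follows the added carbons or the ring itself, and groups such as ethyl, tert-butyl, cyclopropyl or cyclopentyl at this position would help separate those two readings. They also leave open whether the downward step seen with the chloro would still appear on a compound that carries cyclohexyl in place of isopropyl.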